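A few compounds are considered here, and "the series" means these few. Any claim that something is new, unique, unknown or untested is made for them only; others in the source may bear on it.

Compound 1 `CC(O)(COc1cccc(S(F)(F)(F)(F)F)c1)C(=O)Nc1ccc(S(F)(F)(F)(F)F)cc1`: 12000 nM
Compound 2 `CC(O)(COc1cccc(S(F)(F)(F)(F)F)c1)C(=O)Nc1ccc(C(F)(F)F)cc1`: 12800 nM

In a functional assay on LNCaP cells (Homo sapiens) for antiproliferative activity, read by propidium iodide staining, with a stated time of 96 h (a higher number here means a weaker inhibitor, a lower number a stronger inhibitor), compound 1 gives 12000 nM and compound 2 gives 12800 nM. Compound 2 holds the highest of the two numbers, with compound 1 nearest; the step of a 1.1-fold higher number from compound 1 to compound 2 (0.03 log units; within the scatter) lies within the scatter, so the two compounds are not separated. Compound 3 `CC(O)(COc1cccc(C(F)(F)C(F)(F)F)c1)C(=O)Nc1ccc(C(F)(F)F)cc1` is not yet measured in this assay. Its difference from compound 2 is a group of 7 heavy atoms (2 carbon, 5 fluorine; no ring) in place of a group of 6 heavy atoms (5 fluorine, 1 sulfur; no ring), on an aromatic carbon. Among the measured compounds shown here, the only measured step, a 1.1-fold higher number from compound 1 to compound 2 (0.03 log units; within the scatter), also removed a group of 6 heavy atoms (5 fluorine, 1 sulfur) in favour of a fluorinated carbon group on an aromatic carbon, though not at the same aromatic carbon, and left the number within the scatter. For the measured compounds named here, no measured step addresses the aromatic carbon changed here. On that basis no movement beyond the scatter is expected for compound 3 in this assay, and the expected step is a 1.0-fold lower number from compound 2 to compound 3 (0.01 log units; within the scatter). Compound 3 is therefore estimated at 12500 nM, within 5000 nM to 30000 nM.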

Compound 3, half-maximal inhibitory concentration: 3900 nM
The estimate for compound 3 lay 3.2-fold (0.51 log units) above the measured number; measured number outside the range, below it.
By their numbers in this assay, from the lowest: compound 3; then compounds 1 and 2 (each within the scatter of the next).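

In this assay the aromatic carbon meta to a large group proves sensitive to the choice of fluorinated group: 1,1,2,2,2-pentafluoroethyl in place of the group of 6 heavy atoms (5 fluorine, 1 sulfur) gives a 3.3-fold lower number from compound 2 to compound 3 (0.52 log units; beyond the scatter) and so separates two compounds of the series. The earlier exchange at a different aromatic carbon, a 1.1-fold higher number from compound 1 to compound 2 (0.03 log units; within the scatter), did not separate its pair, so the outcome of exchanging this group depends on the aromatic carbon that carries it. Nothing shown accounts for the difference between the two groups at this position.

Going by these compounds, whether a nitrile or a longer perfluoroalkyl chain at this aromatic carbon would continue the step remains open. Also open, on these data alone, is whether the step holds when the other aromatic carbon carries something other than trifluoromethyl.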